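Dioxin ring attachment point in a melanoma cell growth assay

The compounds below may be only part of what the source reports. "The series", "measured", "known", "first", "only" and "open" are said of these compounds alone.

The measured compounds and their values:

Compound 1 `O=C(C1COc2ccccc2O1)N1N=C(c2ccc(Br)cc2)CC1c1ccccc1`: 6150 nM
Compound 2 `O=C(c1ccc2c(c1)OCCO2)N1N=C(c2ccc(Br)cc2)CC1c1ccccc1`: 1790 nM
Compound 3 `O=C(c1ccc2c(c1)OCCO2)N1N=C(c2ccccc2)CC1c1ccc(F)cc1`: 5210 nM

Three compounds were tested in a functional assay on WM 266-4 cells (Homo sapiens) for inhibition, read by MTT assay, with a stated time of 24 h; on this read-out higher numbers stand for weaker inhibition of growth and lower numbers for stronger inhibition of growth. Compound 2 `O=C(c1ccc2c(c1)OCCO2)N1N=C(c2ccc(Br)cc2)CC1c1ccccc1` gives 1790 nM in this assay, while compound 1 `O=C(C1COc2ccccc2O1)N1N=C(c2ccc(Br)cc2)CC1c1ccccc1` gives 6150 nM. The two differ at the carbonyl carbon, where (2,3-dihydro-1,4-benzodioxin-2-yl in place of 2,3-dihydro-1,4-benzodioxin-6-yl on a carbonyl carbon), and this change produced a 3.4-fold higher number from compound 2 to compound 1 (0.54 log units; beyond the scatter). Compound 3 `O=C(c1ccc2c(c1)OCCO2)N1N=C(c2ccccc2)CC1c1ccc(F)cc1` gives 5210 nM in this assay; it shares the same carbonyl group as compound 2, but the difference between the two cores is not broken down here. Against compound 1 the value of compound 3 lies within the scatter, so no order between them can be read.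

Compound 4 `O=C(C1COc2ccccc2O1)N1N=C(c2ccccc2)CC1c1ccc(F)cc1` has not yet been measured. It differs from compound 3 in that (2,3-dihydro-1,4-benzodioxin-2-yl in place of 2,3-dihydro-1,4-benzodioxin-6-yl on a carbonyl carbon), the same change that separates compound 2 from compound 1, made at the same place on the carbonyl carbon. Because the earlier instance gave a 3.4-fold higher number from compound 2 to compound 1 (0.54 log units; beyond the scatter), a step of similar size is expected from compound 3 to compound 4, namely a 2.9-fold higher number from compound 3 to compound 4 (0.46 log units; beyond the scatter). This rests on a single earlier pair, so the range is kept wide. Compound 4 is therefore estimated at 15000 nM in this assay, with an expected range from 6000 nM to 40000 nM.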

Compound 4, concentration for 50% growth inhibition: 3270 nM
Compound 4: middle estimate off by 4.6-fold (0.66 log units), on the high side; measured number outside the range, below it.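

In this assay, exchanging 2,3-dihydro-1,4-benzodioxin-6-yl for 2,3-dihydro-1,4-benzodioxin-2-yl on the carbonyl carbon gave a 1.6-fold lower number from compound 3 to compound 4 (0.20 log units; within the scatter), so this core shows no readable effect of the change. The result from the core of compound 2 therefore did not carry over to the core of compound 3 in this assay, and the identical exchange gave clearly different results on the two cores: the same change on two cores in this assay, a 3.4-fold higher number (0.54 log units; beyond the scatter) from compound 2 to compound 1 and a 1.6-fold lower number (0.20 log units; within the scatter) from compound 3 to compound 4, 5.5-fold (0.74 log units) apart, beyond the scatter of two such steps. This shows that the step depends on the core in this series, at least for these two pairs, but it does not show which feature of the cores is responsible, since they differ in more than one place, nor how the exchange would behave on a third core.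

The compounds shown leave open which of the differences between the two cores goes with the different steps, and a core altered in only one of those places could separate them. They also leave open how the same exchange would run on a core carrying a chlorine atom, a methoxy group or an amine in place of the bromine or fluorine seen here.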